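From compound 2 to compound 4: a side-chain swap

The source may hold more compounds than are shown below. What is called first, only, known or untested is meant among the compounds shown, and "the series" means these compounds.

Measured in a functional assay on HeLa cells (Homo sapiens) for cytotoxicity, read by WST assay, with a stated time of 48 h; a lower number here means a stronger inhibitor, a higher number a weaker inhibitor:
compound 1 `COc1cc(C(c2ccc(O)c(OC)c2)[C@@H](C)C(C)C)ccc1O`: 19000 nM
compound 2 `COC[C@@H](C(C)C)C(c1ccc(O)c(OC)c1)c1ccc(O)c(OC)c1`: 69000 nM
compound 3 `CCCCCCCC[C@H](C(C)C)C(c1ccc(O)c(OC)c1)c1ccc(O)c(OC)c1`: 3100 nM

Of these three, compound 2 has the highest number, so compound 1 and compound 3 both inhibit more strongly. Compound 4 `COc1cc(C(c2ccc(O)c(OC)c2)[C@H](C)[C@@H](C)CO)ccc1O` has not been measured yet. It differs from compound 2 in one side chain: 2-(hydroxymethyl)-1-methylpropyl in place of 1-(methoxymethyl)-2-methylpropyl on a saturated chain carbon bound to two aromatic carbons. Put simply, 2-(hydroxymethyl)-1-methylpropyl stands in place of 1-(methoxymethyl)-2-methylpropyl on a saturated chain carbon bound to two aromatic carbons.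

Going by the values given here, only one measured step bears on this change, and it is modest: a 3.6-fold higher number from compound 1 to compound 2 (0.56 log units; beyond the scatter). That step introduced a methoxy group on the side chain. Among the compounds with values here, compound 4 also carries oxygen in its side chain, but as hydroxymethyl, and no measured compound has that group. The expected step is therefore small, a 1.3-fold lower number from compound 2 to compound 4 (0.10 log units; within the scatter), which means no expected change beyond the scatter. For compound 4 the estimate is 55000 nM, with an expected range from 18000 nM to 150000 nM.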

Compound 4, half-maximal inhibitory concentration: > 100000 nM
Compound 4: a limit, no number; the forecaster's own chance of this, stated with the estimate: 15%; middle value at least 1.8-fold (0.25 log units) from the limit.
By their numbers in this assay, from the lowest: compound 3; then compound 1; then compound 2. At a limit, above all of these: compound 4.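

In this assay, compound 4 gives only a limit, not a number: the limit of > 100000 nM in this assay, at which 1 of the 4 values shown sits. Replacing the oxygen-free 1,2-dimethylpropyl with 2-(hydroxymethyl)-1-methylpropyl gives an at least 5.2-fold higher number from compound 1 to compound 4 (0.72 log units; beyond the scatter), so at this saturated chain carbon bound to two aromatic carbons, a second oxygen-bearing side chain, this one with a hydrogen-bond donor, also raises the number, as the methoxy did with a 3.6-fold higher number from compound 1 to compound 2 (0.56 log units; beyond the scatter). The comparison with the methoxy-bearing side chain is less decisive, with an at least 1.4-fold higher number from compound 2 to compound 4 (0.16 log units; that floor lies within the scatter), so the limit does not show that 2-(hydroxymethyl)-1-methylpropyl is worse than 1-(methoxymethyl)-2-methylpropyl.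

Going by these compounds, how far compound 4 lies beyond its limit remains unknown, which leaves those two side chains unranked. Also open, on these data alone, is whether an amine or a carboxylic acid in this side chain would raise the number too.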